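This account rests on a few compounds, and the source may have more. Where it says the series, first, only, none or still open, it means among the compounds named here.

Compound 1 `Cc1ccccc1-n1nncc1CN1C(=O)C2(C(C#N)=C(N)Oc3c2c2nc4ccccc4nc2c2ccccc32)c2ccccc21`: in a functional assay on A549 cells (Homo sapiens) for antiproliferative activity, read by MTT assay, with a stated time of 48 h (on this read-out lower numbers stand for stronger inhibition and higher numbers for weaker inhibition), compound 1 gives > 50000 nM, a limit of the assay and not a number.
Compound 2 `N#CC1=C(N)Oc2c(c3nc4ccccc4nc3c3ccccc23)C12C(=O)N(Cc1cnnn1-c1ccccc1Br)c1ccccc12`: in this assay compound 2 gives > 50000 nM, again a limit rather than a number.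
Compound 3 `COc1ccc(-n2nncc2CN2C(=O)C3(C(C#N)=C(N)Oc4c3c3nc5ccccc5nc3c3ccccc43)c3ccccc32)cc1`: in this assay compound 3 gives > 50000 nM, also a limit.

Compound 2 therefore stands exactly where the other two stand, at the limit of > 50000 nM in this assay, at which 3 of the 3 values shown sit. On these data alone, none of the three measured steps can be read: a step that the two limits leave unreadable from compound 1 to compound 2, a step that the two limits leave unreadable from compound 1 to compound 3 and a step that the two limits leave unreadable from compound 2 to compound 3 all run between two limits, so their size is unknown, and the three changes on the aryl group attached to the triazole nitrogen give no readable trend at all.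

Compound 4 `Cc1ccc(-n2nncc2CN2C(=O)C3(C(C#N)=C(N)Oc4c3c3nc5ccccc5nc3c3ccccc43)c3ccccc32)cc1Cl` differs from compound 2 in one place: 3-chloro-4-methylphenyl in place of 2-bromophenyl on an aromatic nitrogen. Every change of this aryl group seen so far has left the compound at the limit, so no step beyond the scatter is expected in this assay, and the estimate for compound 4 means a step that the limit leaves unreadable from compound 2 to compound 4. Compound 4 is therefore expected to give about 60000 nM, within a range of 30000 nM to 150000 nM, and most likely only a limit will be reported.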

Compound 4, half-maximal inhibitory concentration: > 50000 nM
Compound 4: only a limit was reported; the forecaster's own chance of this, stated with the estimate: 85%; the middle value lies beyond the limit too.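

In this assay compound 4 gives > 50000 nM, again a limit and not a number. Its steps from compound 1, compound 2 and compound 3 therefore cannot be read: the limit of > 50000 nM in this assay, at which 4 of the 4 values shown sit.

The compounds shown leave open whether the aryl group on the aromatic nitrogen affects the result in this assay at all.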